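The compounds below may be only part of what the source reports. "The series", "measured", "known", "first", "only" and "open" are said of these compounds alone.

Compound 1 `Cc1ccc2nc(Nc3nc(Nc4ccc(S(N)(=O)=O)cc4)ncc3C)sc2c1` gives 2710 nM in a functional assay on PC-3 cells (Homo sapiens) for antiproliferative activity, read by MTT assay, with a stated time of 48 h; a lower number here means a stronger inhibitor, a higher number a weaker inhibitor. Compound 2 `Cc1cnc(Nc2ccc(S(N)(=O)=O)cc2)nc1Nc1nc2ccc(Cl)cc2s1` carries chloro in place of methyl on an aromatic carbon and gives 5400 nM in this assay, a step of a 2.0-fold higher number from compound 1 to compound 2 (0.30 log units; within the scatter). Compound 3 `Cc1ccc2nc(Nc3ccnc(Nc4ccc(S(C)(=O)=O)cc4)n3)sc2c1` rests on a different core; how the two cores differ is not broken down here. In this assay compound 3 returns only a limit, > 50000 nM, rather than a number, and the limit of > 50000 nM in this assay, at which 1 of the 3 values shown sits, marks how many values reach that limit. Compound 4 `CS(=O)(=O)c1ccc(Nc2nccc(Nc3nc4ccc(Cl)cc4s3)n2)cc1` is not yet measured; it stands to compound 3 as compound 2 stands to compound 1, with chloro in place of methyl on an aromatic carbon, the same change at the same place. Since the measured pair moved only by a 2.0-fold higher number from compound 1 to compound 2 (0.30 log units; within the scatter), compound 4 is expected to stay near the limit, an estimated step that the limit leaves unreadable from compound 3 to compound 4. Compound 4 is therefore estimated at 80000 nM, between 20000 nM and 300000 nM.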

Compound 4, half-maximal inhibitory concentration: > 50000 nM
Compound 4: no number, only a limit; the forecaster's own chance of this, stated with the estimate: 85%; the middle value does not contradict the limit.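

In this assay compound 3 and compound 4 each return only a limit, so no step between them can be read: the limit of > 50000 nM in this assay, at which 2 of the 4 values shown sit.

The compounds shown leave open what chloro in place of methyl does on the core of compound 3, and how weak either compound is beyond that limit.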